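Removing the iodo group from compound 3

A few compounds are considered here, and "the series" means these few. Any claim that something is new, unique, unknown or untested is made for them only; others in the source may bear on it.

Measured in a functional assay on THP-1 cells (Homo sapiens) for inhibition, with a stated time of 48 h, tested at 50 uM; a lower number here means less inhibition of growth, a higher number more inhibition of growth at the concentration tested:
- compound 1 `C=C[C@@](C)(/C=C/c1ccc(OC(=O)CCCC)cc1)CCC=C(C)C`: 15%
- compound 2 `C=C[C@@](C)(/C=C/c1ccc(O)c(N)c1)CCC=C(C)C`: 48%
- compound 3 `CC[C@](C)(CCCC(C)C)CCc1ccc(O)c(I)c1`: 58%

Compound 3, at 58%, lies within the scatter of compound 2, at 48%. Its distance from compound 1, at 15%, is beyond the scatter, with compound 3 showing more inhibition of growth.

The next compound is compound 4 `CC[C@](C)(CCCC(C)C)CCc1ccc(O)cc1`. It differs from compound 3 as follows: hydrogen in place of iodo on an aromatic carbon. The change is hydrogen in place of iodo on an aromatic carbon, ortho to a hydroxy group and meta to a large group.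

Within the data shown here, no pair of measured compounds differs in one place only, so the size of this step cannot be read directly from the series. Compound 2 carries no iodo and still gives 48%, so the loss of iodo is not expected to abolish inhibition of growth. However, compound 2 differs from compound 3 in more than one place, which limits this comparison. A moderate fall in this assay is expected, probably somewhat beyond the scatter, though a step within it remains possible.

The expected change is a number 16 percentage points lower from compound 3 to compound 4 (beyond the scatter).

For compound 4 the estimated value is 42%, with an expected range of 22% to 62%.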

Compound 4, percent growth inhibition at one concentration: 58%
Compound 4: the middle estimate sits 16 percentage points below what was measured; the range from low to high includes it.
By their numbers in this assay, from the lowest: compound 1; then compounds 2, 3 and 4 (each within the scatter of the next).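

In this assay, among these compounds, hydrogen in place of iodo on an aromatic carbon, ortho to a hydroxy group and meta to a large group, gives no change at the digits printed from compound 3 to compound 4 (within the scatter) and is the only step that can be read at a single place. At this position, iodo is therefore not required for the inhibition of growth seen at the concentration tested, since compound 4, which carries hydrogen there, gives 58% in this assay. No measurement is available that would explain why the exchange leaves the read-out unchanged.

As far as these compounds go, only hydrogen and iodo can be compared at this position, so it remains open how a methoxy group, a fluoro group or a carboxylic acid there would read in this assay. The step also rests on a single concentration and on the core of compound 3 alone, which leaves open whether compound 3 and compound 4 would also stay within the scatter at lower concentrations, or whether the same exchange would read alike on the core of compound 1.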